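Returning the basic chain to the phenyl substituent

The compounds below may be only part of what the source reports. "The series", "measured", "known", "first", "only" and "open" are said of these compounds alone.

Three compounds share one core and differ only in the chain attached through an oxygen on the phenyl ring. Compound 1 `COc1cc(OC)c2c(=O)cc(-c3ccc(OCCCN(C)C)cc3)oc2c1` carries a 3-(dimethylamino)propoxy chain, compound 2 `COc1cc(OC)c2c(=O)cc(-c3ccc(OCCN)cc3)oc2c1` a 2-aminoethoxy chain, and compound 3 `COc1cc(OC)c2c(=O)cc(-c3ccc(OCC(O)CO)cc3)oc2c1` a 2,3-dihydroxypropoxy chain. In a functional assay (Homo sapiens) for antiproliferative activity, read by resazurin assay, with a stated time of 48 h, tested at 10 uM (a lower number here means a weaker effect, a higher number a stronger effect of the compound at the concentration tested), compound 1 gives 59%, compound 2 gives 35%, and compound 3 gives 11%, the lowest of the three numbers. The steps are a number 24 percentage points lower from compound 1 to compound 2 (beyond the scatter), a number 24 percentage points lower from compound 2 to compound 3 (beyond the scatter) and a number 48 percentage points lower from compound 1 to compound 3 (beyond the scatter).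

Compound 4 `COc1cc(OC)c2c(=O)cc(-c3ccc(NCCN(C)C)cc3)oc2c1` is not yet measured. It differs from compound 3 as follows: (2-(dimethylamino)ethyl)amino in place of 2,3-dihydroxypropoxy on an aromatic carbon. The entering group brings back a dimethylamino terminus on a two-carbon chain, now attached through a nitrogen rather than an oxygen. The step bearing most on this is a number 48 percentage points lower from compound 1 to compound 3 (beyond the scatter), a large fall when the dimethylamino chain was exchanged for the diol; the step of a number 24 percentage points lower from compound 2 to compound 3 (beyond the scatter) adds that the diol sits below even the primary amine. Reversing that exchange, one expects a large rise, of about a number 39 percentage points higher from compound 3 to compound 4 (beyond the scatter). Compound 4 is therefore estimated at 50%, in a range from 25% to 75%.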

Compound 4, a percentage reported as inhibition, at one concentration (the size of the read-out at that concentration, not a potency): 60%
Estimate against measurement, compound 4: 10 percentage points below; the range from low to high includes it.
By their numbers in this assay, from the lowest: compound 3; then compound 2; then compounds 1 and 4 (each within the scatter of the next).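

In this assay, the (2-(dimethylamino)ethyl)amino group on the aromatic carbon gives a number 49 percentage points higher from compound 3 to compound 4 (beyond the scatter) against the 2,3-dihydroxypropoxy chain, and a number 25 percentage points higher from compound 2 to compound 4 (beyond the scatter) against the 2-aminoethoxy chain. Going by these compounds alone, what the earlier compounds did not show is that the oxygen attachment is not required at this position: with a nitrogen attached to the ring and a different chain, the step is a number 1 percentage points higher from compound 1 to compound 4 (within the scatter) and the dimethylamino compounds stay level. Nothing measured here accounts for these steps.

Going by these compounds, compound 1 and compound 4 differ in both the attaching atom and the chain, so the contribution of each remains open, and a 2-(dimethylamino)ethoxy chain or a 3-(dimethylamino)propylamino chain would be needed to separate them. On these data alone, it also remains open whether the dimethylamino terminus could give way to a ring amine such as morpholine or piperidine, and whether compound 1 and compound 4 would still stand level in a full concentration series rather than at the single concentration tested.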